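This account rests on a few compounds, and the source may have more. Where it says the series, first, only, none or still open, it means among the compounds named here.

Compound 1 `CCn1c(C(=O)N[C@H](C)C(=O)OC)ccc1C(CC)(CC)c1ccc(OCS(=O)(=O)c2ccccc2)c(C)c1`: > 50000 nM (a limit)
Compound 2 `CCn1c(C(=O)NCCN)ccc1C(CC)(CC)c1ccc(OCS(=O)(=O)c2ccccc2)c(C)c1`: 6890 nM
Compound 3 `CCn1c(C(=O)N[C@@H](CO)C(C)C)ccc1C(CC)(CC)c1ccc(OCS(=O)(=O)c2ccccc2)c(C)c1`: 10600 nM

These three compounds share one core and differ only in the group carried on an amide-type nitrogen. In a functional assay on PC-3 cells (Homo sapiens) for antiproliferative activity, read by MTT assay, with a stated time of 24 h (on this read-out higher numbers stand for weaker inhibition and lower numbers for stronger inhibition), compound 1 reports only a limit, > 50000 nM, so no number is known for it. Compound 2 gives 6890 nM, the lowest of the two numbers that were actually measured. Compound 3 gives 10600 nM, and the step of a 1.5-fold higher number from compound 2 to compound 3 (0.19 log units; within the scatter) lies within the scatter, so compound 2 and compound 3 cannot be ranked against each other.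

Compound 4 `CCn1c(C(=O)N[C@@H](C)C(=O)O)ccc1C(CC)(CC)c1ccc(OCS(=O)(=O)c2ccccc2)c(C)c1` has not yet been measured. It differs from compound 2 as follows: 1-carboxyethyl in place of 2-aminoethyl on an amide-type nitrogen.

Going by the values given here, two measured steps bear on this change. Replacing the 1-(methoxycarbonyl)ethyl group of compound 1 gave an at least 7.2-fold lower number from compound 1 to compound 2 (0.86 log units; beyond the scatter) and an at least 4.7-fold lower number from compound 1 to compound 3 (0.67 log units; beyond the scatter), both beyond the scatter. The 1-carboxyethyl group entering in compound 4 is the closest relative of the 1-(methoxycarbonyl)ethyl group of compound 1, which reached only (the limit of > 50000 nM in this assay, at which 1 of the 3 values shown sits). A higher number is therefore expected from compound 2 to compound 4, beyond the scatter, roughly a 3.6-fold higher number from compound 2 to compound 4 (0.56 log units; beyond the scatter). Compound 4 is estimated at 25000 nM, within a range from 8000 nM to 60000 nM, and a limit rather than a number is a real possibility.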

Compound 4, half-maximal inhibitory concentration: 16800 nM
Compound 4: middle estimate off by 1.5-fold (0.17 log units), on the high side, and the stated range covers the measured number.
By their numbers in this assay, from the lowest: compounds 2, 3 and 4 (each within the scatter of the next, the first and the last beyond it). At a limit, above all of these: compound 1.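

Swapping the 1-(methoxycarbonyl)ethyl group for 1-carboxyethyl on the amide-type nitrogen gives a measurable number in this assay, with an at least 2.9-fold lower number from compound 1 to compound 4 (0.47 log units; beyond the scatter), so two closely related groups at this position do not behave alike; the stereocentre is also drawn with the opposite sense in these two compounds, so this step cannot be credited to the ester and acid ends alone. Going by these compounds alone, the 1-carboxyethyl group does not match the 2-aminoethyl group, with a 2.4-fold higher number from compound 2 to compound 4 (0.39 log units; beyond the scatter), which is the first step beyond the scatter among the compounds with measured numbers, whereas a 1.6-fold higher number from compound 3 to compound 4 (0.20 log units; within the scatter) leaves compound 3 and compound 4 unranked. Compound 1 remains the only compound reported as a limit: the limit of > 50000 nM in this assay, at which 1 of the 4 values shown sits.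

The compounds shown leave open whether the gain in compound 2 rests on its terminal amine, which a longer chain such as 3-aminopropyl or a 2-hydroxyethyl group would help to test. They also leave open how a methyl ester with the stereocentre drawn as in compound 4 would compare with the carboxylic acid.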